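A few compounds are considered here, and "the series" means these few. Any claim that something is new, unique, unknown or untested is made for them only; others in the source may bear on it.

In an ADME assay on the whole organism (plasma, Rattus norvegicus) for protein binding, using cassette dosing, at a dose of 1 mg/kg (a higher number here means a larger unbound share of the compound, a lower number a smaller unbound share), compound 1 (`Cc1ccc(Cn2c(=O)n(CC(C)(C)C(=O)O)c(=O)[nH]/c2=N\c2ccc(OC(C)C)c(Cl)c2)cc1`) gives 0.01 and compound 2 (`C[C@@H](Cn1c(=O)[nH]/c(=N\c2ccc(Oc3cccc(F)n3)cc2)n(Cc2ccc(Cl)cc2)c1=O)C(=O)O`) gives 0.007. Among the measured compounds shown here, compound 2 therefore stands within the usual scatter of compound 1, the only other compound measured so far. For the measured compounds named here, these two compounds differ in more than one place, so the data contain no single-change step in this assay to use as a guide.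

Compound 3 (`C[C@@H](Cn1c(=O)[nH]/c(=N\c2ccc(OC3CCC3)cc2)n(Cc2ccc(Cl)cc2)c1=O)C(=O)O`) departs from compound 2 in one place: cyclobutyl in place of 6-fluoropyridin-2-yl on an oxygen on an aromatic ring. Cyclobutyl thus stands in place of 6-fluoropyridin-2-yl on an oxygen on an aromatic ring, and the rest of the structure is unchanged.

Going by the values given here, with no measured precedent for this exchange, the expectation rests on how close the two known values are. Compound 1 at 0.01 and compound 2 at 0.007 remain within the scatter despite their several structural differences. No change beyond the scatter is therefore expected in this assay, and the estimated step is a 1.4-fold higher number from compound 2 to compound 3 (0.15 log units; within the scatter). For compound 3 the expected unbound fraction is 0.01, with an estimated range from 0.005 to 0.02.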

Compound 3, unbound fraction: 0.015
Estimate against measurement, compound 3: 1.5-fold (0.18 log units) below; low and high end bracket the measured number.
By their numbers in this assay, from the lowest: compounds 2, 1 and 3 (each within the scatter of the next, the first and the last beyond it).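

Among the compounds shown here, at this position, on an oxygen on an aromatic ring, cyclobutyl in place of 6-fluoropyridin-2-yl gives the first single-change step in this assay with a 2.1-fold higher number from compound 2 to compound 3 (0.33 log units; beyond the scatter) as its size, a modest step that shows this one place can move the unbound fraction beyond the scatter, which the earlier pair, differing in more than one place, could not show. The exchange takes away a six-membered aromatic ring with 1 hetero atom, a fluorine and 1 hydrogen-bond acceptor, and brings in a four-membered non-aromatic ring of carbon only, so several things change together in this one step. No measurement is at hand that explains the step.

The compounds shown do not separate these features, so it remains open whether pyridin-2-yl without the fluorine, phenyl or cyclopentyl on the same oxygen would give a number nearer to that of compound 2 or to that of compound 3. From the compounds shown here alone, it also remains open whether the same exchange would give a step of similar size on the rest of the structure of compound 1.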